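The source may report more compounds than this note shows. Statements on the series, on what has been measured and on what is new or still open speak of the compounds shown alone.

Among the measured compounds shown here, in an ADME assay on MDCK-II cells (Canis lupus familiaris) for permeability (on this read-out higher numbers stand for higher permeability and lower numbers for lower permeability), compound 1 `CC(C)Oc1cc(Oc2ccc(S(C)(=O)=O)cc2)cc(-c2cncc(=O)[nH]2)c1` gives 94 10^-6 cm/s, the highest of the two numbers measured so far. Compound 2 `CC(C)Oc1cc(Oc2cnc(C(=O)N(C)C)nc2)cc(-c2nccc(=O)[nH]2)c1` gives 7.1 10^-6 cm/s in this assay, a lower number by a margin beyond the usual scatter; the two compounds differ in several places at once, so their two values speak only for themselves. Compound 3 `COc1cnc(-c2cc(Oc3ccc(S(C)(=O)=O)cc3)cc(OC(C)C)c2)[nH]c1=O` has not yet been measured in this assay. It differs from compound 1 in one place: a group of 9 heavy atoms (5 carbon, 2 nitrogen, 2 oxygen; one six-membered aromatic ring with 2 hetero atoms) in place of a group of 7 heavy atoms (4 carbon, 2 nitrogen, 1 oxygen; one six-membered aromatic ring with 2 hetero atoms), on an aromatic carbon The entering group carries one more hydrogen-bond acceptor than the group it replaces, while the hydrogen-bond donor count is unchanged. For the measured compounds named here, no measured pair isolates a change of this kind, so the expectation rests on compound 1 and its 94 10^-6 cm/s. The step from compound 1 to compound 3 is expected to be a 1.4-fold lower number from compound 1 to compound 3 (0.16 log units; within the scatter), a downward shift that would sit near the edge of the scatter rather than clearly beyond it. Compound 3 is therefore estimated at 65 10^-6 cm/s, with a range from 30 10^-6 cm/s to 140 10^-6 cm/s.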

Compound 3, apparent permeability: 3.9 10^-6 cm/s
Beside the measured number, compound 3's estimate is 17-fold (1.22 log units) above it, and the stated range ends above it.
By their numbers in this assay, from the lowest: compounds 3 and 2 (each within the scatter of the next); then compound 1.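

In this assay, the group of 9 heavy atoms in place of the group of 7 heavy atoms, on an aromatic carbon of a six-membered aromatic ring of carbon only and meta to an isopropoxy group, gives a 24-fold lower number from compound 1 to compound 3 (1.38 log units; beyond the scatter) as a large step. Among the compounds shown here, this is the first pair here that differs in one place, so it shows what compound 1 and compound 2 could not: a change at this position alone can move the read-out well beyond the scatter, even though both groups hold a six-membered aromatic ring with 2 hetero atoms, one hydrogen-bond donor and no net charge, and differ in the count of heavy atoms and in having 3 rather than 2 hydrogen-bond acceptors. Nothing at hand bears on the reason for this step.

The compounds shown leave open whether a methyl group or a fluorine atom on the same ring, in place of the added carbon and oxygen atoms, would bring a step of similar size. They also leave open whether the same exchange would give a similar step with an amine or a carboxylic acid elsewhere on the shared core.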